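A few compounds are considered here, and "the series" means these few. Any claim that something is new, unique, unknown or untested is made for them only; others in the source may bear on it.

Compound 3 `CCCOC(=O)C1=C(C)NC(=S)NC1c1cccs1` gives 3% in an assay on membranes from HEK293 cells for displacement of a labelled ligand from adenosine receptor A2b (Homo sapiens), read by scintillation counting, with a stated time of 30 min, tested at 1 uM (a higher number here means more inhibition at the concentration tested (going by the name of the read-out), a lower number less inhibition), the lowest of the three numbers in hand. Compound 2 `COC(=O)C1=C(C)NC(=S)NC1c1cccs1` gives 10%, and the change a number 7 percentage points lower from compound 2 to compound 3 (within the scatter) shows that lengthening the ester chain from methyl to propyl did little. Compound 1 `CC1=C(C(=O)OCc2ccccc2)C(c2ccco2)NC(=S)N1`, a benzyl ester carrying a furan ring instead of thiophene, gives 41%, well beyond the scatter from compound 3. Compound 4 `CC1=C(C(=O)OCc2ccccc2)C(c2cccs2)NC(=S)N1` differs from compound 3 by phenyl in place of ethyl on a saturated chain carbon bound to an oxygen next to a carbonyl group, so that the ester becomes the benzyl ester seen in compound 1 while the thiophene of compound 3 stays. Among the measured compounds shown here, no measured step covers propyl to benzyl directly, so the guide is compound 1 with 41%. Compound 4 is therefore expected to rise by about a number 27 percentage points higher from compound 3 to compound 4 (beyond the scatter). Compound 4 is estimated at 30%, between 5% and 55%.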

Compound 4, a percentage reported as inhibition, at one concentration (the size of the read-out at that concentration, not a potency): 45%
Beside the measured number, compound 4's estimate is 15 percentage points below it; low and high end bracket the measured number.
By their numbers in this assay, from the lowest: compounds 3 and 2 (each within the scatter of the next); then compounds 1 and 4 (each within the scatter of the next).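

With the thiophene kept, the benzyl ester stands well clear of the smaller esters: there is a number 42 percentage points higher from compound 3 to compound 4 (beyond the scatter) for propyl to benzyl and a number 35 percentage points higher from compound 2 to compound 4 (beyond the scatter) for methyl to benzyl. The ring on the saturated ring carbon counts for far less, with a number 4 percentage points higher from compound 1 to compound 4 (within the scatter) for thiophen-2-yl in place of furan-2-yl, so among these compounds the higher numbers go with the benzyl ester, not with that ring. No measured evidence here explains the effect of the phenyl. From the compounds shown here alone, whether a longer chain ending in phenyl, or an amine on the phenyl ring, would keep these numbers stays open.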